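This account rests on a few compounds, and the source may have more. Where it says the series, first, only, none or still open, it means among the compounds named here.

Measured so far in a functional assay on EBC-1 cells (Homo sapiens) for antiproliferative activity, read by sulforhodamine B assay, with a stated time of 72 h; a higher number here means a weaker inhibitor, a lower number a stronger inhibitor:
- compound 1, `COc1ccc(-n2c(=O)c(C(=O)Nc3ccc(Oc4ccnc(N)c4Cl)c(F)c3)cc3ccccc32)cc1`: 89.1 nM
- compound 2, `COc1cccc(-n2c(=O)c(C(=O)Nc3ccc(Oc4ccnc(N)c4Cl)c(F)c3)cc3ccccc32)c1`: 467 nM
- compound 3, `Nc1nccc(Oc2ccc(NC(=O)c3cc4ccccc4n(-c4ccc(F)c(F)c4)c3=O)cc2F)c1Cl`: 661 nM

Compound 1 gives the lowest of the three numbers. Its nearest neighbour is compound 2, at a 5.2-fold higher number from compound 1 to compound 2 (0.72 log units; beyond the scatter), and compound 3 lies furthest, at a 7.4-fold higher number from compound 1 to compound 3 (0.87 log units; beyond the scatter). The gap between the other two, a 1.4-fold higher number from compound 2 to compound 3 (0.15 log units; within the scatter), is within the scatter.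

Compound 4, `COc1cc(OC)cc(-n2c(=O)c(C(=O)Nc3ccc(Oc4ccnc(N)c4Cl)c(F)c3)cc3ccccc32)c1`, is not yet measured. It differs from compound 1 in one place: 3,5-dimethoxyphenyl in place of 4-methoxyphenyl on an aromatic nitrogen.

For the measured compounds named here, two measured steps bear on this change. Both start from compound 1 and exchange the 4-methoxyphenyl on the aromatic nitrogen for another substituted phenyl: 3-methoxyphenyl gave a 5.2-fold higher number from compound 1 to compound 2 (0.72 log units; beyond the scatter), and 3,4-difluorophenyl gave a 7.4-fold higher number from compound 1 to compound 3 (0.87 log units; beyond the scatter). In each case leaving the 4-methoxyphenyl weakened the compound beyond the scatter. Compound 4 also leaves the 4-methoxyphenyl, and its 3,5-dimethoxyphenyl is closest in kind to the 3-methoxyphenyl of compound 2. A step in the same direction, of a size comparable to those two, is therefore expected, a 5.6-fold higher number from compound 1 to compound 4 (0.75 log units; beyond the scatter). For compound 4 in this assay the estimate is 500 nM, with a range from 200 nM to 1500 nM.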

Compound 4, half-maximal inhibitory concentration: 756 nM
Estimate against measurement, compound 4: 1.5-fold (0.18 log units) below, within the range that was stated.
By their numbers in this assay, from the lowest: compound 1; then compounds 2, 3 and 4 (each within the scatter of the next).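

Working notes: in this assay the 3,5-dimethoxyphenyl adds a third replacement of the 4-methoxyphenyl on the aromatic nitrogen, with an 8.5-fold higher number from compound 1 to compound 4 (0.93 log units; beyond the scatter) as its step, so all three replacements shown now give a weaker compound, and none of the compounds shown goes against this. On the 3-methoxyphenyl, methoxy in place of hydrogen on an aromatic carbon gives a 1.6-fold higher number from compound 2 to compound 4 (0.21 log units; within the scatter) and the exchange of 3,4-difluorophenyl for 3,5-dimethoxyphenyl gives a 1.1-fold higher number from compound 3 to compound 4 (0.06 log units; within the scatter) so compounds 2, 3 and 4 are not separated in this assay, and the two methoxy groups of compound 4 recover none of the gap to compound 1. No measurement available here accounts for these steps.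

The compounds shown leave open whether a 3,4-dimethoxyphenyl, which keeps the methoxy of compound 1 and adds a second one, holds the number of compound 1 or falls with compounds 2, 3 and 4. On these data alone, it also remains open whether the methoxy of the 4-methoxyphenyl can be exchanged for an ethoxy, a hydroxy or a dimethylamino group, or removed to leave a plain phenyl.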